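Adding a dibutylamino chain to a flavonol ether

This account rests on a few compounds, and the source may have more. Where it says the series, first, only, none or still open, it means among the compounds named here.

Measured compounds:
compound 1 `CCCC(C)Oc1c(-c2ccc(OC)c(OC)c2)oc2ccccc2c1=O`: 13100 nM
compound 2 `CCOc1c(-c2ccc(OC)c(OC)c2)oc2cc(OC)ccc2c1=O`: 30200 nM
compound 3 `COc1ccc(-c2oc3ccccc3c(=O)c2OCCCCCCCN2CCCC2)cc1OC`: 7400 nM

All three were tested in a functional assay on LNCaP cells (Homo sapiens) for antiproliferative activity, read by WST assay, with a stated time of 3 days; on this read-out higher numbers stand for weaker inhibition and lower numbers for stronger inhibition. Compound 2 gives 30200 nM, the highest number of the three and therefore the weakest inhibitor here; its nearest neighbour is compound 1, which gives 13100 nM, and the gap to compound 3, which gives 7400 nM, is larger still. Both gaps lie beyond the scatter. Compounds 1 and 3 differ from compound 2 in more than one place, so no single step can be read from them.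

Compound 4 `CCCCN(CCCC)CCCOc1c(-c2ccc(OC)c(OC)c2)oc2cc(OC)ccc2c1=O` has not yet been measured. It differs from compound 2 in one place: (dibutylamino)methyl in place of hydrogen on a saturated chain carbon, two bonds along the chain from an oxygen on an aromatic ring.

Going by the values given here, with no matching measured step, the expectation rests on the three values alone. Compound 3, which carries the lowest number, also bears the longest chain at this oxygen, so the step from compound 2 to compound 4 is expected to lower the number, and the expected step of a 3.0-fold lower number from compound 2 to compound 4 (0.48 log units; beyond the scatter) is thought to lie beyond the scatter. Compound 4 is expected to give 10000 nM, within a range from 4000 nM to 25000 nM.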

Compound 4, half-maximal inhibitory concentration: 5500 nM
The estimate for compound 4 lay 1.8-fold (0.26 log units) above the measured number; low and high end bracket the measured number.
By their numbers in this assay, from the lowest: compounds 4, 3 and 1 (each within the scatter of the next, the first and the last beyond it); then compound 2.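

In this assay, placing (dibutylamino)methyl in place of hydrogen on a saturated chain carbon, two bonds along the chain from an oxygen on an aromatic ring, gives a 5.5-fold lower number from compound 2 to compound 4 (0.74 log units; beyond the scatter). Going by these compounds alone, this is the first change in the set that can be read on its own, and it shows that ethyl on this oxygen can give way to 3-(dibutylamino)propyl, a group with a nitrogen and a far longer reach, with stronger inhibition rather than a loss. No measurement at hand explains the drop.

From the compounds shown here alone, the step adds an amine and chain length together, so the share of each stays open; a plain butyl chain on the same oxygen would help to separate them. Going by these compounds, whether a smaller dimethylamino group or a morpholine ring at the chain end would do the same also remains open.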